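The compounds below may be only part of what the source reports. "The series", "measured", "known", "first", "only" and "open" are said of these compounds alone.

Among the measured compounds shown here, in a functional assay on the whole organism (strain Kunming) for inhibition, with Mus musculus as the target, in the writhing test, at a dose of 40 mg/kg by the oral route (a lower number here means less inhibition, a higher number more inhibition at the dose given (going by the name of the read-out)), compound 2 `CNC(=O)c1cc(-c2ccc(F)cc2F)ccc1OC(C)=O` gives 29.9%, the highest of the three numbers measured so far. Compound 3 `CC(=O)Oc1ccc(-c2ccc(F)cc2F)cc1C(=O)Nc1cc(C)ccc1C` gives 13.2%, and compound 1 `O=C(Oc1ccc(-c2ccc(F)cc2F)cc1C(=O)O)c1ccccc1` gives 7.97%. For the measured compounds named here, the one step measured between close neighbours is a number 16.7 percentage points lower from compound 2 to compound 3 (beyond the scatter). Compound 4 `CNC(=O)c1cc(-c2ccc(F)cc2F)ccc1OC(=O)c1ccccc1` differs from compound 2 by phenyl in place of methyl on a carbonyl carbon, acetoxy becoming benzoyloxy. Going by the values given here, no measured pair isolates this change; compound 1 carries benzoyloxy but differs from compound 2 elsewhere as well. The only comparable enlargement of a methyl into an aromatic ring lowered the number beyond the scatter, so a drop of similar size is expected, giving a number 14.9 percentage points lower from compound 2 to compound 4 (beyond the scatter). Compound 4 is therefore estimated at 15%, between 5% and 28%.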

Compound 4, a percentage reported as inhibition, in the whole organism at one dose (the size of the read-out at that dose, not a potency): 47.5%
The estimate for compound 4 lay 32.5 percentage points below the measured number; the measured number lies above the stated range.
By their numbers in this assay, from the lowest: compounds 1 and 3 (each within the scatter of the next); then compound 2; then compound 4.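

In this assay, phenyl in place of methyl on this carbonyl carbon gives a number 17.6 percentage points higher from compound 2 to compound 4 (beyond the scatter), so enlarging methyl to an aromatic ring raises the number here, whereas 2,5-dimethylphenyl on the amide-type nitrogen gave a number 16.7 percentage points lower from compound 2 to compound 3 (beyond the scatter). Benzoyloxy alone does not secure a high number: methylamino in place of hydroxy on a carbonyl carbon gives a number 39.5 percentage points higher from compound 1 to compound 4 (beyond the scatter), the largest step so far. Nothing available explains either rise.

Open, from the compounds shown here alone, is how a longer chain such as propanoyl, or a methoxy-bearing phenyl, would fare at this carbonyl carbon.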